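Chloro for Trifluoromethyl on a Weak Orexin Antagonist

The compounds below may be only part of what the source reports. "The series", "measured", "known", "first", "only" and "open" are said of these compounds alone.

Compound 1 `Cc1nc(C(=O)N2CCC3(CC3)C[C@H]2CNc2ccc(C(F)(F)F)cn2)c(-c2ccccc2)s1`: in a functional assay on HEK293 cells for antagonist activity at Orexin receptor type 2 (Homo sapiens), read by FLIPR and calcium flux (on this read-out lower numbers stand for lower potency and higher numbers for higher potency (the scale is a negative logarithm)), compound 1 gives < 5, which is a limit of the assay and not a number.
Compound 2 `O=C(c1ncccc1-c1ncccn1)N1CC2(CC2)C[C@H]1CNc1ccc(C(F)(F)F)cn1`: in this assay compound 2 gives 5.

Compound 1 therefore stands at the floor of what this assay reports; the only thing known about it is the limit of < 5 in this assay, at which 1 of the 2 values shown sits. Compound 2 has a measured number, so the two cannot be ranked against each other. Compound 3 `Cc1nc(C(=O)N2CCC3(CC3)C[C@H]2CNc2ccc(Cl)cn2)c(-c2ccccc2)s1` differs from compound 1 in one place: chloro in place of trifluoromethyl on an aromatic carbon. Within the data shown here, no measured pair differs in just this way, so there is no step to draw on. Compound 1 sits at the limit, and the change is expected to move potency little, if at all, beyond the scatter. The step from compound 1 to compound 3 is expected as a step that the limit leaves unreadable from compound 1 to compound 3. Compound 3 is estimated at 4.8, between 4.2 and 5.5, with a fair chance that this assay again returns only a limit.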

Compound 3, negative logarithm of the antagonist equilibrium constant: < 5
Compound 3: no number, only a limit (the forecaster's own chance of this, stated with the estimate: 60%); the middle value is on the limit's open side.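

Compound 1 and compound 3 both return only a limit in this assay, not a number, so no step between them can be read: the limit of < 5 in this assay, at which 2 of the 3 values shown sit.

What the compounds shown leave open is how far, if at all, chloro in place of trifluoromethyl moves potency.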